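A few compounds are considered here, and "the series" means these few. Any claim that something is new, unique, unknown or untested is made for them only; others in the source may bear on it.

In a physicochemical assay for solubility, measured as kinetic solubility, at pH 2 (a higher number here means a more soluble compound, a lower number a less soluble compound), compound 1 `CC(C)[C@@H](c1ccc(-c2ccc3cccc(F)c3c2)[nH]c1=O)[C@H]1OC(=O)NC1=O` gives 5400 nM and compound 2 `CC(C)[C@H](C[C@H]1SC(=O)NC1=O)c1ccc(-c2ccc3cccc(F)c3c2)[nH]c1=O` gives 4900 nM on the same scale. Within the data shown here, the two stand level: the only measured step is a 1.1-fold lower number from compound 1 to compound 2 (0.04 log units; within the scatter) and it stays within the scatter. Compound 3 `CC(C)[C@@H](C[C@H]1SC(=O)NC1=O)c1ccc(-c2ccc3cccc(F)c3c2)[nH]c1=O` has not yet been measured. Set against compound 2, its structure shows this difference: the two compounds have the same atoms and bonds and differ only in configuration as drawn: 1 of 2 stereo elements differ; a stereocentre at a saturated chain carbon is drawn S in compound 2 and R in compound 3 and nothing more.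

Among the measured compounds shown here, no measured pair isolates a change of configuration, so the data contain no direct precedent for this one. For the measured compounds named here, the single measured step instead placed (2,4-dioxo-1,3-thiazolidin-5-yl)methyl where 2,4-dioxo-1,3-oxazolidin-5-yl had stood, and it offers only indirect guidance. Going by the values given here, the expectation therefore rests on compound 2 at 4900 nM and on a 1.1-fold lower number from compound 1 to compound 2 (0.04 log units; within the scatter) as the sole guide, and no shift beyond the scatter is expected, in either direction. The expected change is a 1.0-fold higher number from compound 2 to compound 3 (0.01 log units; within the scatter) with real uncertainty around it. For compound 3 the estimated reading is 5000 nM within an expected range of 2500 nM to 10000 nM in this assay once it is tested.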

Compound 3, solubility: 12200 nM
Compound 3: the middle estimate sits 2.4-fold (0.39 log units) below what was measured; measured number outside the range, above it.
By their numbers in this assay, from the lowest: compounds 2 and 1 (each within the scatter of the next); then compound 3.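

In this assay, the configuration at this saturated chain carbon turns out to matter: there is a 2.5-fold higher number from compound 2 to compound 3 (0.40 log units; beyond the scatter), a modest step but one beyond the scatter. The earlier compounds gave no sign of this, since their only step, a 1.1-fold lower number from compound 1 to compound 2 (0.04 log units; within the scatter), replaced one ring-bearing group with another and left the readings level, so a change of atoms at this part of the molecule had shown less than the change of configuration alone now shows. The higher number can be assigned to this one stereocentre, drawn R rather than S, because nothing else separates the pair: the fact that compounds 2 and 3 differ only in the configuration as drawn.

What the compounds shown leave open is whether this difference between R and S carries over when the (2,4-dioxo-1,3-thiazolidin-5-yl)methyl group gives way to another group on the same carbon, such as a carboxylic acid, an amine or a longer chain. From the compounds shown here alone, it is also open whether inverting the second stereocentre, which is drawn the same in compound 2 and compound 3, would move the number at all, and a single pair cannot say how general the step is.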